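This account rests on a few compounds, and the source may have more. Where it says the series, first, only, none or still open, it means among the compounds named here.

For the measured compounds named here, in an ADME assay on microsomes from liver (Mus musculus) for metabolic stability, with a stated time of 10 min (on this read-out lower numbers stand for a less stable compound and higher numbers for a more stable compound), compound 2 `O=C(C1CCS(=O)(=O)CC1)N1CC[C@](c2ccc(C(F)(C(F)(F)F)C(F)(F)F)cc2)(S(=O)(=O)c2ccc(F)cc2)C1` gives 96%, the only number it has, with one further entry giving no single number. Compound 1 `O=C(C1CCS(=O)(=O)C1)N1CC[C@](c2ccc(C(F)(C(F)(F)F)C(F)(F)F)cc2)(S(=O)(=O)c2ccc(F)cc2)C1` gives 78%; 96% (2 entries), and that spread the several entries of compound 1 in this assay, 78%; 96% (2 entries) shows how far repeat readings of these compounds can sit apart. Compound 3 `O=C(N1CC[C@](c2ccc(C(F)(C(F)(F)F)C(F)(F)F)cc2)(S(=O)(=O)c2ccc(F)cc2)C1)C1(O)CCS(=O)(=O)CC1` is still unmeasured and differs from compound 2 by hydroxy in place of hydrogen on a saturated ring carbon. Going by the values given here, no measured step speaks to this change, so no shift beyond the scatter is expected, and the estimated step is a number 6 percentage points lower from compound 2 to compound 3 (within the scatter). The expected value for compound 3 is 90%, with a range of 72% to 100%.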

Compound 3, percent of the compound remaining: 90%
Beside the measured number, compound 3's estimate shows no gap at the digits printed; low and high end bracket the measured number.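

In this assay, for the compounds shown here, the first measured change at this carbon reads a number 6 percentage points lower from compound 2 to compound 3 (within the scatter). Hydroxy in place of hydrogen, three ring bonds from the ring sulfur, therefore brings no shift beyond the scatter on this read-out. The step is also small beside the spread of repeat readings: the several entries of compound 1 in this assay, 78%; 96% (2 entries)

Going by these compounds, whether an amine, a methoxy group or a fluorine atom on this carbon would read the same remains open. So does whether hydroxy on the corresponding ring of compound 1 would behave as it does in compound 3.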